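The compounds below may be only part of what the source reports. "The series", "measured", "known", "first", "only" and "open" are said of these compounds alone.

The measured compounds are these. Compound 1, `O=S(=O)(Nc1cccc(CO)c1)c1ccc(-c2ccccc2)cc1`, in a functional assay on J774 cells (Mus musculus) for cytotoxicity, read by resazurin assay, with a stated time of 72 h (a higher number here means a weaker inhibitor, a lower number a stronger inhibitor), gives 2200 nM. Compound 2, `O=S(=O)(Nc1ccc(CO)c(CO)c1)c1ccc(-c2ccc(F)cc2F)cc1`, in this assay gives 150 nM. Compound 3, `O=S(=O)(Nc1ccc(-c2ccc(Cl)cc2Cl)cc1)c1cccc(CO)c1`, in this assay gives only a limit of the assay, > 10000 nM.

Of the two plain numbers, compound 1 holds the higher one, and the gap down to compound 2 lies beyond the usual scatter, so compound 1 is the weaker inhibitor of that pair. Compound 3 reaches no number at all, as noted in the limit of > 10000 nM in this assay, at which 1 of the 3 values shown sits.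

Compound 4, `O=S(=O)(Nc1cccc(CO)c1)c1ccc(-c2ccc(Cl)cc2)cc1`, differs from compound 1 in one place: chloro in place of hydrogen on an aromatic carbon. Going by the values given here, no measured pair shows this change by itself, and compound 2 and compound 3 each differ from compound 1 in more than one place, so neither gives a clean reading. The expected step in this assay is therefore modest, a 1.8-fold lower number from compound 1 to compound 4 (0.26 log units; within the scatter), pointing toward a somewhat stronger inhibitor but close to the scatter. For compound 4 the estimate is 1200 nM, ranging from 400 nM to 4000 nM.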

Compound 4, half-maximal inhibitory concentration: 2500 nM
Compound 4: middle estimate off by 2.1-fold (0.32 log units), on the low side; low and high end bracket the measured number.
By their numbers in this assay, from the lowest: compound 2; then compounds 1 and 4 (each within the scatter of the next). At a limit, above all of these: compound 3.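

Phenyl to 4-chlorophenyl is the first single change that can be read in this assay, and it gives a 1.1-fold higher number from compound 1 to compound 4 (0.06 log units; within the scatter) with no difference that stands out from the scatter. At this position, on an aromatic carbon para to a large group, this pair therefore shows that adding a chloro leaves the reading indistinguishable from that of the parent compound. Nothing measured here offers a reason for this result.

Still open, as far as these compounds go, is whether a different group in the same place, such as an amine, a carboxylic acid or a longer chain like propyl, would give a step beyond the scatter. Also open, from the compounds shown here alone, is whether a chloro on another carbon of the same ring would read the same way in this assay as it does here.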